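The compounds below may be only part of what the source reports. "The series", "measured", "known", "first", "only" and "open" are said of these compounds alone.

Compound 1 `O=C(CCc1cccc2c1B(O)OC2)Nc1ccc(Br)cc1` and compound 2 `C#Cc1cccc(NC(=O)CCc2cccc3c2B(O)OC3)c1` share one core. In an ADME assay on WI-38 cells (Homo sapiens) for cytotoxicity, read by MTT assay, with a stated time of 72 h (a higher number here means a weaker inhibitor, a lower number a stronger inhibitor), compound 1 gives 42000 nM. In this assay compound 2 gives > 100000 nM, which is a limit of the assay and not a number. Compound 2 therefore stands at the limit of > 100000 nM in this assay, at which 1 of the 2 values shown sits. Compound 3 `CC(=O)c1cccc(-c2cccc(NC(=O)CCc3cccc4c3B(O)OC4)c2)c1` differs from compound 2 by 3-acetylphenyl in place of ethynyl on an aromatic carbon. For the measured compounds named here, no measured step covers a change of this kind, so in this assay no shift beyond the usual scatter is expected in either direction. Compound 3 is expected to give 70000 nM, with a range from 25000 nM to 200000 nM. The estimated step from compound 2 to compound 3 is an at least 1.4-fold lower number from compound 2 to compound 3 (0.15 log units; that floor lies within the scatter).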

Compound 3, half-maximal inhibitory concentration: 2200 nM
Estimate against measurement, compound 3: 32-fold (1.50 log units) above; measured number outside the range, below it.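

In this assay, 3-acetylphenyl in place of ethynyl on an aromatic carbon, meta to a large group, gives an at least 45-fold lower number from compound 2 to compound 3 (1.65 log units; beyond the scatter). This position therefore affects cytotoxicity in the series, and a larger aromatic group here goes with a stronger reading. The size of the step is only a floor, as the value of compound 2 is a limit of the assay: the limit of > 100000 nM in this assay, at which 1 of the 3 values shown sits.

The compounds shown do not separate the contribution of the added aromatic ring from that of the acetyl group. A plain phenyl or a carboxylic acid on that ring would address this.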